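Swapping the Side Chain on an Acetyltransferase Binder

A few compounds are considered here, and "the series" means these few. Any claim that something is new, unique, unknown or untested is made for them only; others in the source may bear on it.

Of the compounds shown here, three have been tested in an assay for inhibition of histone acetyltransferase KAT2B (Homo sapiens), read by TR-FRET, with a stated time of 10 min, tested at 50 uM; on this read-out higher numbers stand for more inhibition at the one concentration tested (going by the name of the read-out) and lower numbers for less inhibition. Compound 1 `COC(=O)CCN1C(=O)/C(=C/c2cc(OC)ccc2OC)SC1=S` gives 8%, compound 3 `CC1=C/C(=N/Nc2ccnc3cc(Cl)ccc23)CC1` gives 12%, and compound 2 `Cc1cccc(NC(=O)CN2C(=O)/C(=C3\SC(=S)N(CCS(=O)(=O)O)C3=O)c3ccccc32)c1` gives 6%. All three numbers sit within the usual scatter of one another, so compound 2 cannot be told apart from the other two on these results. Compound 4 `Cc1ccc(CN2C(=O)/C(=C3\SC(=S)N(CCS(=O)(=O)O)C3=O)c3ccccc32)cc1` differs from compound 2 in one place: 4-methylphenyl in place of (3-methylphenyl)carbamoyl on a saturated chain carbon bound to an amide-type nitrogen in a ring. Going by the values given here, no measured pair here differs in only one place, so there is no step of known size to lean on. Since every number shown is small, the step expected in this assay is none beyond the scatter, a number 2 percentage points higher from compound 2 to compound 4 (within the scatter). Compound 4 is therefore estimated at 8%, within 0% to 20%.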

Compound 4, a percentage reported as inhibition, at one concentration (the size of the read-out at that concentration, not a potency): < 5%
Compound 4 gave a limit, no number; the forecaster's own chance of this, stated with the estimate: 0%; at least 3 percentage points between middle value and limit.
By their numbers in this assay, from the lowest: compounds 2, 1 and 3 (each within the scatter of the next). At a limit, below all of these: compound 4.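

In this assay, going by these compounds alone, this is the first pair differing in one place, and it gives a step at the saturated chain carbon bound to an amide-type nitrogen in a ring: a number at least 1 percentage points lower from compound 2 to compound 4 (that floor lies within the scatter). The reading for compound 4 is a limit of the assay, not a number: the limit of < 5% in this assay, at which 1 of the 4 values shown sits. Exchanging (3-methylphenyl)carbamoyl for 4-methylphenyl therefore does not separate the two groups, and neither gives more than a small reading.

The compounds shown leave open whether an amine or a carboxylic acid at this place would read any differently. They also leave open what a longer chain would do there.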